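Moving the Chlorine Around the Arylsulfanyl Ring

A few compounds are considered here, and "the series" means these few. Any claim that something is new, unique, unknown or untested is made for them only; others in the source may bear on it.

Of the compounds shown here, three sharing one core have been measured in a functional assay for inhibition of sodium/hydrogen exchanger (Oryctolagus cuniculus); a lower number here means a stronger inhibitor, a higher number a weaker inhibitor. Compound 1 `Cc1cc(Br)c(S(C)(=O)=O)cc1C(=O)N=C(N)N` gives 12 nM, compound 2 `Cc1cc(C2CCC2)c(S(C)(=O)=O)cc1C(=O)N=C(N)N` gives 8.2 nM, and compound 3 `Cc1cc(Sc2cccc(Cl)c2)c(S(C)(=O)=O)cc1C(=O)N=C(N)N` gives 37 nM. Compound 3 therefore stands highest of the three: the change from bromo to (3-chlorophenyl)sulfanyl gave a 3.1-fold higher number from compound 1 to compound 3 (0.49 log units; beyond the scatter), and that from cyclobutyl to (3-chlorophenyl)sulfanyl gave a 4.5-fold higher number from compound 2 to compound 3 (0.65 log units; beyond the scatter), while a 1.5-fold lower number from compound 1 to compound 2 (0.17 log units; within the scatter) separates compounds 1 and 2.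

Compound 4 `Cc1cc(Sc2ccccc2Cl)c(S(C)(=O)=O)cc1C(=O)N=C(N)N` has not yet been measured. It differs from compound 3 by 2-chlorophenyl in place of 3-chlorophenyl on a sulfur. Going by the values given here, none of the measured steps touches this part of the molecule; they compare the whole arylsulfanyl group with bromo or cyclobutyl, not one chlorophenyl with another. There is thus no measured ground for expecting a shift in either direction, and the expectation is a step of no size beyond the scatter, no change at the digits printed from compound 3 to compound 4 (within the scatter), in this assay.

Compound 4 is therefore estimated at 37 nM, with a range from 12 nM to 110 nM.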

Compound 4, half-maximal inhibitory concentration: 14 nM
Beside the measured number, compound 4's estimate is 2.6-fold (0.42 log units) above it; the measured number falls inside the stated range.
By their numbers in this assay, from the lowest: compounds 2, 1 and 4 (each within the scatter of the next); then compound 3.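

Moving the chlorine alone, with the same atoms joined differently, registers in this assay: 2-chlorophenyl in place of 3-chlorophenyl on the sulfur gives a 2.6-fold lower number from compound 3 to compound 4 (0.42 log units; beyond the scatter) and so the earlier comparisons of the whole arylsulfanyl group with bromo or cyclobutyl depended on which chlorophenyl was carried. The (2-chlorophenyl)sulfanyl group stands level with bromo (a 1.2-fold higher number from compound 1 to compound 4 (0.07 log units; within the scatter)) and with cyclobutyl (a 1.7-fold higher number from compound 2 to compound 4 (0.23 log units; within the scatter)), so the shortfall of compound 3 is not shared by compound 4. Nothing measured here speaks to why the place of the chlorine matters.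

Open, on these data alone, is how a plain phenyl on the sulfur, or a methoxy or fluoro group in the chlorine's stead, would read in this assay as a result. Also open, as far as these compounds go, is whether the shift between the two chlorophenyl groups would persist with an oxygen in place of the sulfur.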